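Changing the ring-nitrogen substituent: compound 3 to compound 4

The source may hold more compounds than are shown below. What is called first, only, known or untested is meant among the compounds shown, and "the series" means these compounds.

- compound 1 `CN1CCN(c2cc(C(F)(F)F)nc(SCc3ccc(C(F)(F)F)cc3)n2)CC1`: 15800 nM
- compound 2 `FC(F)(F)c1ccc(CSc2nc(N3CCN(c4ccccc4)CC3)cc(C(F)(F)F)n2)cc1`: 35200 nM
- compound 3 `CC(C)(C)OC(=O)N1CCN(c2cc(C(F)(F)F)nc(SCc3ccc(C(F)(F)F)cc3)n2)CC1`: 22200 nM

In a functional assay on MGC-803 cells (Homo sapiens) for inhibition, read by MTT assay, with a stated time of 72 h (on this read-out lower numbers stand for stronger inhibition and higher numbers for weaker inhibition), compound 3 gives 22200 nM, a value within the scatter of both other compounds. Compound 4 `FC(F)(F)c1ccc(CSc2nc(N3CCN(c4ccccn4)CC3)cc(C(F)(F)F)n2)cc1` differs from it by one change, pyridin-2-yl in place of tert-butoxycarbonyl on an amine nitrogen in a ring. Three measured steps at this same place bear on it. Two stay within the scatter: a 1.4-fold higher number from compound 1 to compound 3 (0.15 log units; within the scatter) and a 1.6-fold lower number from compound 2 to compound 3 (0.20 log units; within the scatter). The third, a 2.2-fold higher number from compound 1 to compound 2 (0.35 log units; beyond the scatter), is modest and lies beyond the scatter. Among the compounds with values here, no measured compound carries pyridin-2-yl. The nearest measured group is phenyl, and compound 2, which bears it, gives 35200 nM. With steps this small at this place, no step beyond the scatter is expected in this assay. The expected step is a 1.2-fold higher number from compound 3 to compound 4 (0.09 log units; within the scatter). Compound 4 is estimated at 27000 nM, with an expected range from 13000 nM to 55000 nM.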

Compound 4, half-maximal inhibitory concentration: 23500 nM
The estimate for compound 4 lay 1.1-fold (0.06 log units) above the measured number; the range from low to high includes it.
By their numbers in this assay, from the lowest: compounds 1, 3, 4 and 2 (each within the scatter of the next, the first and the last beyond it).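

In this assay, pyridin-2-yl on the amine nitrogen in the ring cannot be told apart from the other three groups: a 1.1-fold higher number from compound 3 to compound 4 (0.02 log units; within the scatter), a 1.5-fold lower number from compound 2 to compound 4 (0.18 log units; within the scatter) and a 1.5-fold higher number from compound 1 to compound 4 (0.17 log units; within the scatter). A six-membered aromatic ring with 1 hetero atom thus reads the same here as phenyl, ring-free tert-butoxycarbonyl and methyl, so neither that ring nor its hetero atom separates compounds in this set. Within the data shown here, compound 4 lies within the scatter of both compound 1 and compound 2, leaving a 2.2-fold higher number from compound 1 to compound 2 (0.35 log units; beyond the scatter) as the only step at this place beyond the scatter, and no supporting measurement accounts for this narrow spread.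

Going by these compounds, whether a free secondary amine, a carboxylic acid or a longer hydroxyalkyl chain on this nitrogen would give a step beyond the scatter remains open. Also open, on these data alone, is whether replacing either trifluoromethyl group on the shared core would matter more than changes at this nitrogen.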